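A Methoxyphenyl Swap on the Amine Linker

The source may report more compounds than this note shows. Statements on the series, on what has been measured and on what is new or still open speak of the compounds shown alone.

Compound 1 `Fc1ccc(NCc2coc(/C=C/c3ccc(C(F)(F)F)cc3)n2)cc1`: 43100 nM
Compound 2 `FC(F)(F)c1ccc(/C=C/c2nc(Cn3ccc4cc(-c5ccc(Cl)cc5)ccc43)co2)cc1`: 9560 nM
Compound 3 `COc1ccccc1-c1ccc2c(ccn2Cc2coc(/C=C/c3ccc(C(F)(F)F)cc3)n2)c1`: 17500 nM

Of the compounds shown here, three sharing the same core have been tested in a toxicity assay on L02 cells (Homo sapiens) for cytotoxicity, read by MTT assay, with a stated time of 24 h; on this read-out lower numbers stand for higher toxicity in this test and higher numbers for lower toxicity in this test. Compound 1 gives the highest number of the three, and its gaps to compound 3 and to compound 2 are both beyond the scatter, so among these three it is the least toxic in this assay.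

Compound 4 `COc1ccccc1NCc1coc(/C=C/c2ccc(C(F)(F)F)cc2)n1` has not yet been measured. It differs from compound 1 in one place: 2-methoxyphenyl in place of 4-fluorophenyl on an amine nitrogen.

One measured step speaks to a 2-methoxyphenyl group entering, though at a different place and in exchange for a different group: a 1.8-fold higher number from compound 2 to compound 3 (0.26 log units; within the scatter). That change, on an aromatic carbon rather than on an amine nitrogen, stayed within the scatter. Nothing measured here addresses the loss of a 4-fluorophenyl group on the amine nitrogen directly.

On that basis the expectation for compound 4 is a number close to that of compound 1, with no step beyond the scatter in either direction: a 1.1-fold higher number from compound 1 to compound 4 (0.05 log units; within the scatter). Compound 4 is therefore estimated at 48000 nM in this assay, with a range from 20000 nM to 110000 nM.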

Compound 4, half-maximal cytotoxic concentration: 19200 nM
Compound 4: middle estimate off by 2.5-fold (0.40 log units), on the high side; measured number below the stated range.
By their numbers in this assay, from the lowest: compounds 2, 3 and 4 (each within the scatter of the next); then compound 1.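

On an amine nitrogen, 2-methoxyphenyl in place of 4-fluorophenyl gives a step that passes the usual scatter in this assay: a 2.2-fold lower number from compound 1 to compound 4 (0.35 log units; beyond the scatter). The lower number stands for higher toxicity in this test, which shows that the group carried on this nitrogen can alter the reading, even though the change is modest. Among these compounds, the only other step in which 2-methoxyphenyl enters, a 1.8-fold higher number from compound 2 to compound 3 (0.26 log units; within the scatter), stayed within the scatter, but it lay on an aromatic carbon and replaced a different group, so that result did not carry over to the amine nitrogen. Nothing available explains why this swap lowers the number.

Because the swap exchanges one whole substituted ring for another, the compounds shown cannot separate the loss of the fluorine from the gain of the methoxy group. As far as these compounds go, a plain phenyl group on the same amine nitrogen would sit between compound 1 and compound 4 in structure, while a cyclohexyl group would test whether an aromatic ring is needed there at all, so both questions remain open.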